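The source may report more compounds than this note shows. Statements on the series, on what has been measured and on what is new or still open speak of the compounds shown alone.

Measured so far in a functional assay on HepG2 cells (Homo sapiens) for cytotoxicity, read by MTT assay, with a stated time of 48 h; a higher number here means a weaker inhibitor, a lower number a stronger inhibitor:

compound 1, `COc1cc(-c2nc3ccc([N+](=O)[O-])cc3[nH]2)cc(-c2nc3ccc([N+](=O)[O-])cc3[nH]2)c1`, 8900 nM
compound 2, `O=[N+]([O-])c1cc(-c2nc3ccc([N+](=O)[O-])cc3[nH]2)cc(-c2nc3ccc([N+](=O)[O-])cc3[nH]2)c1`, 11100 nM
compound 3, `COc1cc(-c2nc3ccc(C(F)(F)F)cc3[nH]2)cc(-c2nc3ccc(C(F)(F)F)cc3[nH]2)c1`, 10700 nM

Compounds 1 and 2 share a core and differ in one place, (nitro in place of methoxy on an aromatic carbon). The step of a 1.2-fold higher number from compound 1 to compound 2 (0.10 log units; within the scatter) is small. Compound 3 carries a different core; the difference between the core of compound 1 and the core of compound 3 is not broken down here, and the two values of compound 1 and compound 3 lie close together. Compound 3 and compound 2 give numbers that are close as well, so the three measured compounds sit in one band.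

Compound 4, `O=[N+]([O-])c1cc(-c2nc3ccc(C(F)(F)F)cc3[nH]2)cc(-c2nc3ccc(C(F)(F)F)cc3[nH]2)c1`, is not yet measured. Compound 4 differs from compound 3 by nitro in place of methoxy on an aromatic carbon, which is the same change as that from compound 1 to compound 2, at the same kind of place. For compound 4 the expected step of a 1.2-fold higher number from compound 3 to compound 4 (0.07 log units; within the scatter) rests on the earlier step of a 1.2-fold higher number from compound 1 to compound 2 (0.10 log units; within the scatter), which stayed within the scatter. Compound 4 is therefore expected to give about 12500 nM in this assay, with a likely range from 7000 nM to 22000 nM.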

Compound 4, half-maximal inhibitory concentration: 4100 nM
Estimate against measurement, compound 4: 3.0-fold (0.48 log units) above, and the stated range ends above it.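

In this assay, nitro in place of methoxy on the core of compound 3 gives a 2.6-fold lower number from compound 3 to compound 4 (0.42 log units; beyond the scatter), whereas the same change left the number within the scatter on the core of compound 1. The change therefore does not carry over as a fixed step between these two cores: the same change on two cores in this assay, a 1.2-fold higher number (0.10 log units; within the scatter) from compound 1 to compound 2 and a 2.6-fold lower number (0.42 log units; beyond the scatter) from compound 3 to compound 4, 3.3-fold (0.51 log units) apart, beyond the scatter of two such steps

This rests on a single pair for each core, so it shows only that the outcome of the change depended on the core in these two cases. It does not show which feature of the cores is responsible, and it gives no direction or size for the change on any further core.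

With only methoxy and nitro shown on this aromatic carbon, it remains open whether the lower number on the core of compound 3 is particular to nitro or would also appear with another group there, such as an amine or a carboxylic acid. A third core carrying the same pair of groups would show whether either of the two steps is the more typical.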